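Sulfonyl variation on a shared core: notes toward compound 4

The source may hold more compounds than are shown below. What is called first, only, known or untested is meant among the compounds shown, and "the series" means these compounds.

Compound 1 `O=S(=O)(c1ccccc1F)c1cn(C2CCNC2)c2ncccc12`: 2 nM
Compound 2 `O=S(=O)(c1ccc(F)cc1)c1cn(C2CCNC2)c2ncccc12`: 8.5 nM
Compound 3 `O=S(=O)(c1cccc(Br)c1)c1cn(C2CCNC2)c2ncccc12`: 1.3 nM

In an assay on HeLa cells for displacement of a labelled ligand from 5-hydroxytryptamine receptor 6 (Homo sapiens) (a lower number here means a stronger inhibitor, a higher number a weaker inhibitor), compound 3 shows the lowest number of the three. Its nearest neighbour is compound 1, with a 1.5-fold lower number from compound 1 to compound 3 (0.19 log units; within the scatter); the furthest is compound 2, with a 6.5-fold lower number from compound 2 to compound 3 (0.82 log units; beyond the scatter). Between the two fluorophenyl compounds stands a 4.3-fold higher number from compound 1 to compound 2 (0.63 log units; beyond the scatter). All three measured steps only move a halogen around a phenyl on the sulfonyl sulfur.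

Compound 4 `O=S(=O)(Cc1ccc(Cl)s1)c1cn(C2CCNC2)c2ncccc12` differs from compound 3 as (5-chlorothiophen-2-yl)methyl in place of 3-bromophenyl on a sulfonyl sulfur. Among the measured compounds shown here, no measured step bears on this exchange: none of the three replaces the aromatic ring itself or inserts a methylene between the sulfonyl sulfur and the ring, so the measured steps give no direction for it. Given that the three measured compounds span a narrow range in this assay, compound 4 is expected to land near them but with a wider band of uncertainty, the expected step being a 3.8-fold higher number from compound 3 to compound 4 (0.59 log units; beyond the scatter). The estimate for compound 4 is 5 nM, between 1 nM and 30 nM.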

Compound 4, inhibition constant: 1 nM
For compound 4 the middle estimate is 5.0-fold (0.70 log units) above the measured one; the measured number falls inside the stated range.
By their numbers in this assay, from the lowest: compounds 4, 3 and 1 (each within the scatter of the next); then compound 2.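

Earlier steps only moved a halogen around a phenyl, whereas this change replaces the ring and adds a methylene on the sulfonyl sulfur, and the number in this assay stays level with the two closest compounds (a 1.3-fold lower number from compound 3 to compound 4 (0.11 log units; within the scatter); a 2.0-fold lower number from compound 1 to compound 4 (0.30 log units; within the scatter)). The (5-chlorothiophen-2-yl)methyl group therefore fits with the 3-bromophenyl and 2-fluorophenyl compounds, while the 4-fluorophenyl compound stays apart (an 8.5-fold lower number from compound 2 to compound 4 (0.93 log units; beyond the scatter)). No measurement shown here accounts for this result.

The compounds shown leave open whether the thiophene ring, its chlorine or the methylene carries the result, and a plain benzyl group on the sulfonyl sulfur would help separate these. As far as these compounds go, how a carboxylic acid or an amine on the aromatic ring would read in this assay also remains open.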